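The source may hold more compounds than are shown below. What is called first, only, known or untested is meant among the compounds shown, and "the series" means these compounds.

Compound 3 `O=C(O)c1ccc(COc2ccc(CN3C(=O)CC[C@H]3C(=O)NCc3ccccc3)cc2)cc1` stands in an assay on HEK293 cells for inhibition of Ataxin-2 (Mus musculus), read by fluorescence and Amplex Red (on this read-out lower numbers stand for stronger inhibition and higher numbers for weaker inhibition), only at a limit, > 5000 nM. Compound 2 `O=C(NCc1ccccc1)[C@@H]1CCC(=O)N1Cc1ccccc1` likewise gives no number in this assay, only the limit > 5000 nM. Compound 1 `CC1(C)OB(c2ccc(COc3ccc(CNC(=O)[C@@H]4CCC(=O)N4Cc4ccccc4)cc3)cc2)OC1(C)C` gives 50 nM in this assay. The step that the two limits leave unreadable from compound 2 to compound 3 therefore has no readable size, because the limit of > 5000 nM in this assay, at which 2 of the 3 values shown sit, hides both ends of it. Compound 4 `O=C(NCc1ccccc1)[C@@H]1CCC(=O)N1Cc1ccc(OCc2ccc(-c3nn[nH]n3)cc2)cc1` differs from compound 3 by 2H-tetrazol-5-yl in place of carboxy on an aromatic carbon. Within the data shown here, none of the measured steps touches this change, so nothing in the data points to a shift in either direction for compound 4. The author expects compound 4 to remain at or near the limit and estimates 6000 nM in this assay, within 1500 nM to 20000 nM, which would make the step that the limit leaves unreadable from compound 3 to compound 4 an expected change of no reliable size.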

Compound 4, half-maximal inhibitory concentration: > 5000 nM
Compound 4: a limit, no number; the forecaster's own chance of this, stated with the estimate: 65%; the middle value is on the limit's open side.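

Among these compounds, compound 4 also gives only a limit, so no step from compound 3 to compound 4 can be read in this assay: the limit of > 5000 nM in this assay, at which 3 of the 4 values shown sit. On these data alone, whether carboxy and 2H-tetrazol-5-yl differ at all remains open, as does how far compound 3 and compound 4 lie beyond the limit.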